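Shortening the ether chain from phenethyl to phenyl

This account rests on a few compounds, and the source may have more. Where it says the series, first, only, none or still open, it means among the compounds named here.

Compound 1, `CCC1(Cc2ccccc2)OS(=O)(=O)C=C1OCc1ccc(F)cc1`: >= 50000 nM
Compound 2, `CCC1(Cc2ccccc2)OS(=O)(=O)C=C1OCC1CCCCC1`: >= 200000 nM
Compound 3, `CCC1(Cc2ccccc2)OS(=O)(=O)C=C1OCCCc1ccccc1`: >= 20000 nM

The three measured compounds share one core and differ only in the group on a saturated chain carbon bound to an oxygen on an unsaturated carbon. In an ADME assay on HEL cells (Homo sapiens) for cytotoxicity, with a stated time of 3 days (a higher number here means that more compound is tolerated, a lower number that less compound is tolerated), compound 1 gives >= 50000 nM, which is a limit of the assay rather than a number. Compound 2 gives >= 200000 nM, also a limit. Compound 3 gives >= 20000 nM, again a limit. Compound 3 thus stands at the limit of >= 20000 nM in this assay, at which 1 of the 3 values shown sits, and no measured number exists for it. The steps that involve it, a step that the two limits leave unreadable from compound 1 to compound 3 and a step that the two limits leave unreadable from compound 2 to compound 3, cannot be read in size or direction, since both ends are limits.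

Compound 4, `CCC1(Cc2ccccc2)OS(=O)(=O)C=C1OCc1ccccc1`, has not been measured. (phenyl in place of phenethyl on a saturated chain carbon bound to an oxygen on an unsaturated carbon). The measured steps give no readable size for any exchange at this position, so no movement beyond the scatter can be predicted from them. Because compound 3 shows only a limit at >= 20000 nM, compound 4 is expected to stay at or above that limit as well. Compound 4 is estimated at 50000 nM, between 20000 nM and 200000 nM. The expected step that the limit leaves unreadable from compound 3 to compound 4 is therefore treated as none beyond the scatter.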

Compound 4, minimum cytotoxic concentration: >= 50000 nM
Compound 4 ended at the assay's limit; the forecaster's own chance of this, stated with the estimate: 85%; the middle value sits exactly at the limit.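

In this assay compound 4 gives >= 50000 nM, which is a limit of the assay and not a number. Within the data shown here, compound 1, compound 2 and compound 3 also show only limits, so no step from any of them to compound 4 can be read. The compounds shown leave open whether exchanging this ether group changes the tolerated concentration at all.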